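Amide nitrogen change from compound 2 to compound 4

The source may hold more compounds than are shown below. What is called first, only, known or untested is meant among the compounds shown, and "the series" means these compounds.

Measured so far in an ADME assay on BaF3 cells (Mus musculus) for antiproliferative activity, read by CCK-8 assay, with a stated time of 72 h; on this read-out lower numbers stand for stronger inhibition of growth and higher numbers for weaker inhibition of growth:
compound 1 `O=C(CCSc1ccc2c(/C=C/c3ccccn3)n[nH]c2c1)Nc1cccc(F)c1`: 6590 nM
compound 2 `Cc1cccc(NC(=O)CCSc2ccc3c(/C=C/c4ccccn4)n[nH]c3c2)c1`: > 10000 nM (a limit)
compound 3 `CN1CCN(c2cccc(NC(=O)CCSc3ccc4c(/C=C/c5ccccn5)n[nH]c4c3)c2)CC1`: > 10000 nM (a limit)

Compound 2 stands only at a limit, > 10000 nM, which is not a number. Compound 3 also gives a limit, > 10000 nM. The set as a whole sits largely at the limit of > 10000 nM in this assay, at which 2 of the 3 values shown sit.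

The next structure is compound 4 `O=C(CCSc1ccc2c(/C=C/c3ccccn3)n[nH]c2c1)NCc1cccc(C(F)(F)F)c1`, and the change is 3-(trifluoromethyl)benzyl in place of 3-methylphenyl on an amide-type nitrogen. In words, 3-(trifluoromethyl)benzyl stands in place of 3-methylphenyl on an amide-type nitrogen.

Three measured steps are nearby. The first is an at least 1.5-fold higher number from compound 1 to compound 2 (0.18 log units; that floor lies within the scatter). The second is an at least 1.5-fold higher number from compound 1 to compound 3 (0.18 log units; that floor lies within the scatter). The third is a step that the two limits leave unreadable from compound 2 to compound 3. All three change a group on an aromatic carbon, and none changes the group on the amide-type nitrogen, so they bear on this change only indirectly. For the measured compounds named here, compound 1, at 6590 nM, is the only measured number in the set, and it gives no reason to expect a large gain.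

In this assay no step beyond the scatter is expected, and the estimated step is a number no higher from compound 2 to compound 4 (the limit leaves the size open). The estimated value for compound 4 is 10000 nM, with an expected range of 3000 nM to 30000 nM.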

Compound 4, concentration for 50% growth inhibition: 8030 nM
The estimate for compound 4 lay 1.2-fold (0.10 log units) above the measured number; the measured number falls inside the stated range.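

Working notes on the amide-type nitrogen. In this assay, compound 2 gives > 10000 nM, which is a limit and not a number. For the compounds shown here, the first change at this position, 3-(trifluoromethyl)benzyl in place of 3-methylphenyl, gives an at least 1.2-fold lower number from compound 2 to compound 4 (0.09 log units; that floor lies within the scatter), so the true size of this step remains unknown and its readable floor shows no real gain. Compared with the 3-fluorophenyl group, the same 3-(trifluoromethyl)benzyl group gives a 1.2-fold higher number from compound 1 to compound 4 (0.09 log units; within the scatter), so this position accepts a benzyl group with no change beyond the scatter, and the series stays weak in this read-out.

As far as these compounds go, whether an amine, a carboxylic acid or a longer chain on the amide-type nitrogen could move the number beyond the scatter remains open. Room for reading further steps is also limited, with much of the set still at the assay limit: the limit of > 10000 nM in this assay, at which 2 of the 4 values shown sit.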